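This account rests on a few compounds, and the source may have more. Where it says the series, first, only, none or still open, it means among the compounds named here.

Going by the values given here, in a functional assay on HeLa cells (Homo sapiens) for inhibition, read by CCK-8 assay, with a stated time of 48 h (a lower number here means a stronger inhibitor, a higher number a weaker inhibitor), compound 2 `COc1ccc(-c2cc3nccc(-c4cc(OC)c(OC)c(OC)c4)n3n2)cc1` gives 373 nM and holds the lower of the two numbers so far, while compound 1 `COc1cc(-c2ccnc3cc(-c4ccc(C(F)(F)F)cc4)nn23)cc(OC)c1OC` gives 1840 nM as its result. Compound 3 `CCOC(=O)c1ccc(-c2cc3nccc(-c4cc(OC)c(OC)c(OC)c4)n3n2)cc1` keeps the core of compound 2 and changes one group, with ethoxycarbonyl in place of methoxy on an aromatic carbon at the same place where compound 1 and compound 2 differ. Among the compounds with values here, only one measured step bears on that place, namely a 4.9-fold lower number from compound 1 to compound 2 (0.69 log units; beyond the scatter) as trifluoromethyl gave way to methoxy, and it is modest but beyond the scatter. Ethoxycarbonyl itself has no measurement yet, so this single step is a loose guide. Losing the methoxy is expected to give a modest rise in this assay of about a 2.4-fold higher number from compound 2 to compound 3 (0.38 log units; beyond the scatter) as an estimate. Compound 3 is therefore expected at 900 nM with an estimated range from 300 nM to 2700 nM for its value.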

Compound 3, half-maximal inhibitory concentration: > 10000 nM
Compound 3: only a limit was reported; the forecaster's own chance of this, stated with the estimate: 4%; middle value at least 11-fold (1.04 log units) away from the limit.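

Going by these compounds alone, the position on the aromatic ring para to a large group turns out to be far less forgiving than the single earlier step suggested: in this assay, ethoxycarbonyl in place of methoxy gives an at least 26-fold higher number from compound 2 to compound 3 (1.42 log units; beyond the scatter). Ethoxycarbonyl also falls behind trifluoromethyl, the weaker of the two earlier groups, with an at least 5.4-fold higher number from compound 1 to compound 3 (0.73 log units; beyond the scatter), so the choice of group here can cost much more activity than compound 1 and compound 2 alone revealed. The number for compound 3 is a limit of the assay, not a measured value: the limit of > 10000 nM in this assay, at which 1 of the 3 values shown sits.

As far as these compounds go, how much activity compound 3 retains, if any, remains unknown, as does whether the loss follows the carbonyl or the ethyl part of the ester. A carboxylic acid, an amide or a simple ethoxy group at this place could help to separate those two parts.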